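1-Methoxy-1-methylethyl replacing (tert-butoxy)methyl in compound 1

This account rests on a few compounds, and the source may have more. Where it says the series, first, only, none or still open, it means among the compounds named here.

In a functional assay on a cell-free system (plasma, Homo sapiens), with a stated time of 3 min (a lower number here means a stronger inhibitor, a higher number a weaker inhibitor), three compounds have been measured so far. Compound 1 (`CC(C)(C)OC[C@@H](O)C(=O)N1[C@H](C(=O)NCc2cc(Cl)ccc2-n2cnnn2)C[C@@H]2C[C@@H]21`) gives 500 nM, compound 2 (`O=C(NCc1cc(Cl)ccc1-n1cnnn1)[C@@H]1CCNN1C(=O)[C@H](O)c1ccccc1`) gives 930 nM and compound 3 (`CC(C)CC[C@@H](O)C(=O)N1N=CC[C@H]1C(=O)NCc1cc(Cl)ccc1-n1cnnn1`) gives 630 nM. Compound 1 lies within the scatter of both compound 2 and compound 3, so the three cannot be ranked.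

Compound 4 (`COC(C)(C)[C@@H](O)C(=O)N1[C@H](C(=O)NCc2cc(Cl)ccc2-n2cnnn2)C[C@@H]2C[C@@H]21`) keeps the core of compound 1 and changes one group. 1-Methoxy-1-methylethyl takes the place of (tert-butoxy)methyl, on a saturated chain carbon bound to a carbonyl carbon and an oxygen on a saturated carbon: 1-methoxy-1-methylethyl in place of (tert-butoxy)methyl on a saturated chain carbon bound to a carbonyl carbon and an oxygen on a saturated carbon.

For the measured compounds named here, no two measured compounds differ in only one place, so no measured step speaks directly to this change. Going by the values given here, the only guide is the spread of the series: compound 2 at 930 nM and compound 3 at 630 nM both stay within the scatter of compound 1 at 500 nM, although their structures differ from it. The expectation in this assay is therefore no step beyond the scatter, with a slight lean towards a weaker inhibitor. The expected change is a 1.2-fold higher number from compound 1 to compound 4 (0.08 log units; within the scatter). For compound 4 the estimated value is 600 nM, with an expected range of 200 nM to 1800 nM.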

Compound 4, half-maximal inhibitory concentration: 1000 nM
For compound 4 the middle estimate is 1.7-fold (0.22 log units) below the measured one; low and high end bracket the measured number.
By their numbers in this assay, from the lowest: compounds 1, 3, 2 and 4 (each within the scatter of the next).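

In this assay the series now has its first step between compounds that differ in one place: a 2.0-fold higher number from compound 1 to compound 4 (0.30 log units; within the scatter). On a saturated chain carbon bound to a carbonyl carbon and an oxygen on a saturated carbon, 1-methoxy-1-methylethyl can therefore stand in for (tert-butoxy)methyl without a step beyond the scatter, even though the group goes from 6 heavy atoms to 5 and its ether oxygen sits in a different place within the group; neither group has a ring, a net charge or a hydrogen-bond donor, and both have the same hydrogen-bond acceptor count. No supporting measurement bears on why the reading stays within the scatter for this change.

Still open, going by these compounds, is whether a group of another kind at this position, such as an amine, a carboxylic acid or a longer alkyl chain, would give a step beyond the scatter. Also open, on these data alone, is whether the same exchange of 1-methoxy-1-methylethyl for (tert-butoxy)methyl would read the same way on a core other than that of compound 1.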